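A few compounds are considered here, and "the series" means these few. Any claim that something is new, unique, unknown or untested is made for them only; others in the source may bear on it.

Measured so far in a functional assay on PC-9 cells (Homo sapiens) for antiproliferative activity, read by luminescence, with a stated time of 72 h; a higher number here means a weaker inhibitor, a lower number a stronger inhibitor:
- compound 1, `NC(=O)Nc1ccc2ncnc(Nc3ccc(F)c(Cl)c3)c2c1`, gives 961 nM
- compound 2, `CC(=O)Nc1ccc2ncnc(Nc3ccc(F)c(Cl)c3)c2c1`, gives 225 nM
- compound 3, `CC(=O)Nc1ccc2ncnc(Nc3ccc(OCc4cccc(F)c4)c(Cl)c3)c2c1`, gives 662 nM

Compound 3 stands second highest of the three numbers. Its nearest neighbour is compound 1, the gap being within the usual scatter, so no order between those two is claimed. Compound 2 lies clearly apart from it, as the step of a 2.9-fold higher number from compound 2 to compound 3 (0.47 log units; beyond the scatter) shows; that step concerns the ether at the aniline ring and is already built into compound 3.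

Compound 4, `O=C(NCCN1CCCCC1)Nc1ccc2ncnc(Nc3ccc(OCc4cccc(F)c4)c(Cl)c3)c2c1`, is not yet measured. It differs from compound 3 in one place: (2-(piperidin-1-yl)ethyl)amino in place of methyl on a carbonyl carbon. Among the measured compounds shown here, the only measured step that touches this carbonyl carbon is a 4.3-fold lower number from compound 1 to compound 2 (0.63 log units; beyond the scatter), in which amino gave way to methyl. For the measured compounds named here, the change to compound 4 runs the opposite way, from methyl back to a nitrogen-bearing substituent, although now a substituted one carrying a piperidine-bearing chain rather than a plain amino group; no measured pair covers a substituted urea of this kind, so the reversal of that step is only a rough guide. On that guide a modest rise in the number is expected for compound 4, about a 1.7-fold higher number from compound 3 to compound 4 (0.22 log units; within the scatter), with wide uncertainty in both directions. Compound 4 is estimated at 1100 nM, in a range from 250 nM to 4500 nM.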

Compound 4, half-maximal inhibitory concentration: 1580 nM
Beside the measured number, compound 4's estimate is 1.4-fold (0.16 log units) below it; the range from low to high includes it.
By their numbers in this assay, from the lowest: compound 2; then compounds 3, 1 and 4 (each within the scatter of the next, the first and the last beyond it).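

In this assay, the carbonyl carbon accepts (2-(piperidin-1-yl)ethyl)amino in place of methyl with only a modest loss, a 2.4-fold higher number from compound 3 to compound 4 (0.38 log units; beyond the scatter), so growth at this position from a single heavy atom to a chain of 9 heavy atoms ending in a piperidine ring does not abolish antiproliferative activity. Methyl now gives the lower number in both pairs that vary this carbonyl substituent, the other being a 4.3-fold lower number from compound 1 to compound 2 (0.63 log units; beyond the scatter), and neither pair goes against this, although the two pairs carry different groups on the aromatic carbon where fluoro and (3-fluorobenzyl)oxy were exchanged. No measurement here bears on the cause of the new step.

From the compounds shown here alone, it remains open whether the rise follows from the urea nitrogen itself or from the chain it carries, a question that a plain amino group on the (3-fluorobenzyl)oxy scaffold would help to separate. Equally open, going by these compounds, is how a shorter chain, a dimethylamino end group or a morpholine in place of the piperidine would read at this carbonyl carbon.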